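Adding a Neopentylamino Group to a Sulfonyl Ethyl Chain

A few compounds are considered here, and "the series" means these few. Any claim that something is new, unique, unknown or untested is made for them only; others in the source may bear on it.

Three compounds share one core and differ only in the group on the sulfonyl sulfur. In an ADME assay on microsomes from liver (Rattus norvegicus) for metabolic stability, with a stated time of 10 min (on this read-out higher numbers stand for a more stable compound and lower numbers for a less stable compound), compound 1 `O=C(NS(=O)(=O)c1ccc(F)cc1)c1ccc(Nc2nc(NC3(c4ccc(Cl)cc4)CC3)nc(OCC(F)(F)F)n2)cc1` gives 99%. Compound 2 `CC(C)(C)OC(=O)NCCS(=O)(=O)NC(=O)c1ccc(Nc2nc(NC3(c4ccc(Cl)cc4)CC3)nc(OCC(F)(F)F)n2)cc1` gives 93% in this assay, and compound 3 `CCS(=O)(=O)NC(=O)c1ccc(Nc2nc(NC3(c4ccc(Cl)cc4)CC3)nc(OCC(F)(F)F)n2)cc1` gives 85%. The step of a number 14 percentage points lower from compound 1 to compound 3 (beyond the scatter) separates compound 3 from compound 1, while the step of a number 8 percentage points lower from compound 2 to compound 3 (within the scatter) leaves compound 3 and compound 2 indistinguishable.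

Compound 4 `CC(C)(C)CNCCS(=O)(=O)NC(=O)c1ccc(Nc2nc(NC3(c4ccc(Cl)cc4)CC3)nc(OCC(F)(F)F)n2)cc1` differs from compound 3 by neopentylamino in place of hydrogen on a saturated chain carbon, two bonds along the chain from a sulfonyl sulfur. The closest measured comparison is the step of a number 8 percentage points lower from compound 2 to compound 3 (within the scatter), which removed a group from this same chain carbon and moved the number only within the scatter. Adding a different group at that position is therefore expected to move this assay little, if at all, and the step of a number 3 percentage points higher from compound 3 to compound 4 (within the scatter) is the expected outcome. Compound 4 is estimated at 88% in this assay, with a likely range from 72% to 98%.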

Compound 4, percent of the compound remaining: 90%
Beside the measured number, compound 4's estimate is 2 percentage points below it, within the range that was stated.
By their numbers in this assay, from the lowest: compounds 3, 4, 2 and 1 (each within the scatter of the next, the first and the last beyond it).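

Neopentylamino on this saturated chain carbon brings in 6 heavy atoms, yet the read-out in this assay stays within the scatter of the plain ethyl compound (a number 5 percentage points higher from compound 3 to compound 4 (within the scatter)), and exchanging tert-butoxycarbonyl for neopentyl on the amine nitrogen also stays within it (a number 3 percentage points lower from compound 2 to compound 4 (within the scatter)). Compound 4 also lies within the scatter of the 4-fluorophenyl compound (a number 9 percentage points lower from compound 1 to compound 4 (within the scatter)), so the 2-(neopentylamino)ethyl group joins the 2-((tert-butoxycarbonyl)amino)ethyl group in showing no readable separation from compound 1. No available evidence bears on the reason for these small steps.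

On these data alone, it remains open whether a primary amine or a carboxylic acid at this chain carbon would give a similar number. A longer chain between the sulfonyl sulfur and the amine nitrogen is also untested among the compounds shown.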